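Hydroxy Step Among Inactive Thiosulfate Sulfurtransferase Amides

The source may hold more compounds than are shown below. What is called first, only, known or untested is meant among the compounds shown, and "the series" means these compounds.

Three amides of related build have been measured in an assay on isolated protein for inhibition of thiosulfate sulfurtransferase (Homo sapiens), with a stated time of 60 min, in the absence of a further agent; a lower number here means a stronger inhibitor, a higher number a weaker inhibitor. Compound 1 `O=C(Nc1cccc(Cl)c1)c1cccc(Br)c1` is the smallest of them. In this assay compound 1 gives > 100000 nM, a limit of the assay rather than a number. Compound 3 `O=C(Nc1ccc(Sc2nc3ccccc3s2)c(Cl)c1)c1cccc(Br)c1` shares the amide with compound 1, but the difference between the two cores is not broken down here. In this assay compound 3 gives > 100000 nM, again a limit. Compound 2 `O=C(Nc1ccc(Sc2nc3ccccc3s2)c(Cl)c1)c1cccc(Br)c1O` arises from compound 3 by hydroxy in place of hydrogen on an aromatic carbon. In this assay compound 2 gives > 100000 nM, also a limit. The step that the two limits leave unreadable from compound 3 to compound 2 therefore has no readable size, because every value of the set sits at the limit of > 100000 nM in this assay, at which 3 of the 3 values shown sit.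

Compound 4 `O=C(Nc1cccc(Cl)c1)c1cccc(Br)c1O` has not yet been measured. It arises from compound 1 by hydroxy in place of hydrogen on an aromatic carbon, the same change as that from compound 3 to compound 2, with the place described in the same words. Since the earlier step could not be read, no size can be carried over from it; what can be said rests on the fact that both compound 1 and compound 2, which already carries the hydroxy group, sit at the limit. The step from compound 1 to compound 4 is expected to be a step that the limit leaves unreadable from compound 1 to compound 4. Compound 4 is expected to give about 200000 nM in this assay, with the likely range running from 50000 nM to 1000000 nM, and most probably only a limit will be reported.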

Compound 4, half-maximal inhibitory concentration: > 100000 nM
Compound 4 gave a limit, no number (the forecaster's own chance of this, stated with the estimate: 85%); the middle value does not contradict the limit.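

No size can be read for the hydroxy step between compound 1 and compound 4, or for any other step in the set, because all of the compounds stand at a limit and not at a number: the limit of > 100000 nM in this assay, at which 4 of the 4 values shown sit.

The compounds shown leave open whether hydroxy in place of hydrogen alters inhibition in either pair, and how strongly, if at all, any of these amides acts in this assay.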